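This account rests on a few compounds, and the source may have more. Where it says the series, first, only, none or still open, it means among the compounds named here.

Compound 1 `Cn1c(=O)c(S(=O)(=O)c2ccc(F)cc2F)cc2cnc(Nc3ccc4cc[nH]c4c3)nc21` gives 5000 nM in a functional assay on K562 cells (Homo sapiens) for inhibition, read by trypan blue exclusion, with a stated time of 72 h; a lower number here means a stronger inhibitor, a higher number a weaker inhibitor.
Compound 2 `Cn1c(=O)c(S(=O)(=O)c2ccc(F)cc2F)cc2cnc(Nc3cccc4[nH]ccc34)nc21` gives 1500 nM in this assay.
Compound 3 `Cn1c(=O)c(S(=O)(=O)c2ccc(F)cc2F)cc2cnc(Nc3ccc4occc4c3)nc21` gives 15000 nM in this assay.

Among these three, compound 2 stands lowest in this assay: the step from it to its nearest neighbour is a 3.3-fold lower number from compound 1 to compound 2 (0.52 log units; beyond the scatter) read in reverse, and the step to the furthest is a 10-fold higher number from compound 2 to compound 3 (1.00 log units; beyond the scatter), both beyond the scatter. The other measured step, a 3.0-fold higher number from compound 1 to compound 3 (0.48 log units; beyond the scatter), is also modest.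

Compound 4 `Cn1c(=O)c(S(=O)(=O)c2ccc(F)cc2)cc2cnc(Nc3cccc4[nH]ccc34)nc21` differs from compound 2 in one place: hydrogen in place of fluoro on an aromatic carbon

All three measured steps change the aromatic amine attached to the shared core, and none of them touches the (2,4-difluorophenyl)sulfonyl group. For the measured compounds named here, no measured step therefore bears on the change from compound 2 to compound 4, and the data give no guide to its direction. The expectation for compound 4 is a step of no change at the digits printed from compound 2 to compound 4 (within the scatter) in this assay, that is, no change beyond the scatter. Compound 4 is thus estimated at 1500 nM, within a range from 500 nM to 4500 nM.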

Compound 4, half-maximal inhibitory concentration: 750 nM
Estimate against measurement, compound 4: 2.0-fold (0.30 log units) above; the measured number falls inside the stated range.
By their numbers in this assay, from the lowest: compounds 4 and 2 (each within the scatter of the next); then compound 1; then compound 3.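

For the compounds shown here, compound 4 gives the first measured change at the (2,4-difluorophenyl)sulfonyl group, as every earlier step changed the aromatic amine. In this assay, the result is a 2.0-fold lower number from compound 2 to compound 4 (0.30 log units; within the scatter), so on this aromatic carbon, ortho to a large group, hydrogen in place of fluoro gives no change beyond the scatter when the 1H-indol-4-yl group is present. No measurement offered here explains this result.

The compounds shown leave open whether a larger replacement at this position, such as chloro, methyl or methoxy, would also stay within the scatter, and whether the remaining fluoro group of the (4-fluorophenyl)sulfonyl group could be replaced by hydrogen. They also leave open whether hydrogen in place of fluoro would give the same result with the 1H-indol-6-yl or 1-benzofuran-5-yl group.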